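Swapping a Phenyl for Ethyl on a Trifluoromethyl Ketone

The source may report more compounds than this note shows. Statements on the series, on what has been measured and on what is new or still open speak of the compounds shown alone.

Of the compounds shown here, two have been measured in an assay on isolated protein for inhibition of liver carboxylesterase 1 (Homo sapiens), read by radioligand binding; a higher number here means a weaker inhibitor, a lower number a stronger inhibitor. Compound 1 `O=C(CCCCCCc1ccccc1)c1nnc(-c2ccncc2)o1` gives 30 nM. Compound 2 `O=C(CCCCCCCc1ccccc1)C(F)(F)F` gives 5 nM, the lowest of the two numbers and well beyond the scatter from compound 1. The next compound, compound 3 `CCCCCCCCCC(=O)C(F)(F)F`, differs from compound 2 by a single change: ethyl in place of phenyl on a saturated chain carbon, seven bonds along the chain from a carbonyl carbon. Among the measured compounds shown here, no measured pair shows this kind of change, so the step from compound 2 must be judged without a precedent. A modest rise in the number is expected, roughly at the edge of the scatter, giving a 3.0-fold higher number from compound 2 to compound 3 (0.48 log units; beyond the scatter). For compound 3 the estimated value in this assay is 15 nM, with a likely range from 3 nM to 60 nM.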

Compound 3, half-maximal inhibitory concentration: 10 nM
Compound 3: the middle estimate sits 1.5-fold (0.18 log units) above what was measured; the measured number falls inside the stated range.
By their numbers in this assay, from the lowest: compounds 2 and 3 (each within the scatter of the next); then compound 1.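

On this saturated chain carbon, seven bonds along the chain from a carbonyl carbon, ethyl in place of phenyl gives a 2.0-fold higher number from compound 2 to compound 3 (0.30 log units; within the scatter) in this assay. A phenyl ring at this place is therefore not required for a number in this range, as the ring-free compound 3 reads 10 nM. Nothing available explains why the two groups read alike.

Still open, as far as these compounds go, is how a carboxylic acid or an amine at this place would read. A longer chain or a shorter chain in place of this one is equally untested here.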